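Swapping Nitro for Carboxy: One Step, Expected Weaker

A few compounds are considered here, and "the series" means these few. Any claim that something is new, unique, unknown or untested is made for them only; others in the source may bear on it.

The study covers two measured compounds and one still to be measured, all read in an assay for inhibition of Tryptophan 2,3-dioxygenase (Homo sapiens), with stated times of 10 min and 60 min; on this read-out lower numbers stand for stronger inhibition and higher numbers for weaker inhibition. Compound 1, `O=[N+]([O-])c1ccccc1CNc1cc(Br)cc2cn[nH]c12`, gives only a limit in this assay: its value of > 100000 nM is the limit of the measurement and not a number. Within the data shown here, compound 2, `O=[N+]([O-])c1cccc(CNc2cc(C(F)(F)F)cc3[nH]ncc23)c1`, is the only compound with a true number, giving 5170 nM in this assay, so it stands as the sole fixed point; the rest of the picture is the limit of > 100000 nM in this assay, at which 1 of the 2 values shown sits. Compound 3, `O=C(O)c1cccc(CNc2cc(C(F)(F)F)cc3[nH]ncc23)c1`, carries a single change from compound 2: carboxy in place of nitro on an aromatic carbon. Among the measured compounds shown here, no step between measured compounds is available to say how such a change behaves; the comparison records a shift in hydrogen-bond donors and acceptors, and nothing more is known of its effect. The writer expects a modest loss in this assay for compound 3, with the step of a 2.9-fold higher number from compound 2 to compound 3 (0.46 log units; beyond the scatter) lying beyond the scatter, though not far beyond it. For compound 3 the writer estimates 15000 nM in this assay, within a range from 3000 nM to 80000 nM.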

Compound 3, half-maximal inhibitory concentration: 1690 nM
Beside the measured number, compound 3's estimate is 8.9-fold (0.95 log units) above it; the measured number lies below the stated range.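

Among these compounds, the carboxy in place of nitro on an aromatic carbon, meta to a large group, gives the first step that can be read in this assay, and it runs toward stronger inhibition: a 3.1-fold lower number from compound 2 to compound 3 (0.49 log units; beyond the scatter). This position on the six-membered aromatic ring of carbon only therefore accepts a carboxy without any loss in this read-out, and the step lies beyond the usual scatter while remaining modest in size, so the nitro is not needed here for the activity seen in this pair. The two compounds differ in their counts of hydrogen-bond donors and acceptors, but nothing measured here bears on why the number moved in this direction.

Going by these compounds, this rests on a single pair, so it remains open whether the step would hold on a core carrying a group other than trifluoromethyl, or with the carboxy elsewhere on the ring. On these data alone, it is equally open how a primary amide, a methyl ester or a nitrile at the same place would compare with the carboxy.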